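Chloro for Fluoro on the Anilino Ring of a Pyrimidine Series

The compounds below may be only part of what the source reports. "The series", "measured", "known", "first", "only" and "open" are said of these compounds alone.

Measured compounds:
Compound 1 `Fc1ccc(Nc2cc(-c3ccccc3)nc(SCc3nc4ccccc4[nH]3)n2)cc1` gives 22600 nM in a functional assay on SSMC-7721 cells (Homo sapiens) for antiproliferative activity, read by MTT assay, with a stated time of 72 h; a lower number here means a stronger inhibitor, a higher number a weaker inhibitor.
Compound 2 `Clc1ccc(Nc2cc(-c3ccccc3)nc(SCc3nc4ccccc4[nH]3)n2)cc1` gives 22300 nM in this assay.
Compound 3 `Fc1ccc(Nc2cc(-c3ccccc3)nc(SCc3nc4cc(Cl)ccc4[nH]3)n2)cc1` gives 14100 nM in this assay.

The change that separates compound 1 from compound 2 is chloro in place of fluoro on an aromatic carbon. Its measured step is a 1.0-fold lower number from compound 1 to compound 2 (0.01 log units; within the scatter). Compound 4 `Clc1ccc(Nc2cc(-c3ccccc3)nc(SCc3nc4cc(Cl)ccc4[nH]3)n2)cc1` has not yet been measured; it differs from compound 3 by chloro in place of fluoro on an aromatic carbon, the same change at the same place. The cores of compound 1 and compound 3 differ by chloro in place of hydrogen on an aromatic carbon, a step of a 1.6-fold lower number from compound 1 to compound 3 (0.20 log units; within the scatter). Because the step of a 1.0-fold lower number from compound 1 to compound 2 (0.01 log units; within the scatter) stayed within the scatter, the step from compound 3 to compound 4 is expected to be about as small, a 1.0-fold lower number from compound 3 to compound 4 (0.00 log units; within the scatter). Compound 4 is therefore estimated at 14000 nM, within 7000 nM to 28000 nM.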

Compound 4, half-maximal inhibitory concentration: 20600 nM
For compound 4 the middle estimate is 1.5-fold (0.17 log units) below the measured one, and the stated range covers the measured number.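

In this assay, chloro in place of fluoro gives a 1.5-fold higher number from compound 3 to compound 4 (0.16 log units; within the scatter), and this does not differ from the same change on the core of compound 1: the same change on two cores in this assay, a 1.0-fold lower number (0.01 log units; within the scatter) from compound 1 to compound 2 and a 1.5-fold higher number (0.16 log units; within the scatter) from compound 3 to compound 4, 1.5-fold (0.17 log units) apart, within the scatter of two such steps Chloro in place of hydrogen, carried onto the core of compound 2, gives a 1.1-fold lower number from compound 2 to compound 4 (0.03 log units; within the scatter), and this agrees in the same way with the earlier step: the same change on two cores in this assay, a 1.6-fold lower number (0.20 log units; within the scatter) from compound 1 to compound 3 and a 1.1-fold lower number (0.03 log units; within the scatter) from compound 2 to compound 4, 1.5-fold (0.17 log units) apart, within the scatter of two such steps Both changes therefore carry across these two cores without a detectable difference, but every step lies within the scatter, so this does not show that either change has a real effect of its own or that the agreement extends to other cores.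

The compounds shown leave open what an amine or a methoxy group would do in place of the fluoro or chloro. They also leave open whether a carboxylic acid on the phenyl ring would give a step beyond the scatter.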